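Adding a Methyl to the Amide Chain of Compound 1

The source may hold more compounds than are shown below. What is called first, only, known or untested is meant among the compounds shown, and "the series" means these compounds.

Compound 1 `C=CC1=C(C(=O)NCCC)C(c2ccc(F)cc2)OC1` carries a propyl group on its amide and a single fluorine on the ring attached to the core. In a functional assay on SW480 cells (Homo sapiens) for cytotoxicity, read by MTT assay, with a stated time of 24 h (a lower number here means a stronger inhibitor, a higher number a weaker inhibitor), compound 1 reaches only a limit of the assay, > 100000 nM, and no number. Two related compounds have been tested in this assay. Compound 2 `C=CC1=C(C(=O)NCc2ccccc2)C(c2ccc(OC)c(OC)c2)OC1`, which carries a benzyl group on the amide and methoxy groups on its ring, also gives only a limit, > 100000 nM. Compound 3 `C=CC1=C(C(=O)NCCC)C(c2ccc(Cl)c(Cl)c2)OC1`, with the propyl amide and chlorine atoms on its ring, likewise sits at a limit, > 100000 nM. Every value shown is thus a limit (the limit of > 100000 nM in this assay, at which 3 of the 3 values shown sit), and no order among the three compounds can be read from these numbers.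

Compound 4 `C=CC1=C(C(=O)NCC(C)C)C(c2ccc(F)cc2)OC1` differs from compound 1 by methyl in place of hydrogen on a saturated chain carbon bound to two saturated chain carbons, so the propyl amide becomes an isobutyl amide. No step between measured compounds is known, and nothing shown points to a shift in either direction. The expected step that the limit leaves unreadable from compound 1 to compound 4 is therefore none beyond the scatter, because compound 1 gives > 100000 nM. Compound 4 is expected to give 200000 nM, within a range of 100000 nM to 1000000 nM, most likely again reported only as a limit.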

Compound 4, half-maximal inhibitory concentration: > 100000 nM
Compound 4 was reported as a limit (the forecaster's own chance of this, stated with the estimate: 85%); the middle value does not contradict the limit.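

No step can be read between compound 1 and compound 4, because both stop at a limit in this assay: the limit of > 100000 nM in this assay, at which 4 of the 4 values shown sit.

The compounds shown leave open whether any compound on the shared core gives a measurable value in this assay, and whether the amide chain or the ring groups would then change it.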